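Removing a Methoxy Group from a Bis-indole Quinone

The source may hold more compounds than are shown below. What is called first, only, known or untested is meant among the compounds shown, and "the series" means these compounds.

Of the compounds shown here, three built on the same bromine-bearing quinone core have been measured in a functional assay on MDA-MB-231 cells (Homo sapiens) for antiproliferative activity, read by CCK-8 assay, with a stated time of 48 h; a lower number here means a stronger inhibitor, a higher number a weaker inhibitor. Compound 1 `Cc1ccc(-c2[nH]c3ccccc3c2C2=C(Br)C(=O)C(Br)=C(Br)C2=O)cc1` gives 21.6 ug/mL. Compound 2 `Cc1[nH]c2ccccc2c1C1=C(Br)C(=O)C(c2c(C)[nH]c3ccccc23)=C(Br)C1=O` gives 5.55 ug/mL, and compound 3 `COc1ccc2[nH]c(C)c(C3=C(Br)C(=O)C(c4c(-c5ccccc5)[nH]c5ccccc45)=C(Br)C3=O)c2c1` gives 5.02 ug/mL. Of these three numbers, compound 3 holds the smallest, but its gap to compound 2 lies within the usual scatter of repeated measurements, so these two cannot be told apart; only compound 1 stands clearly apart, with a number beyond the scatter from compound 3. Among the compounds with values here, no pair among the measured compounds differs in a single place, so no single-change step has been observed here.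

Compound 4 `Cc1[nH]c2ccccc2c1C1=C(Br)C(=O)C(c2c(-c3ccccc3)[nH]c3ccccc23)=C(Br)C1=O` differs from compound 3 in one place: hydrogen in place of methoxy on an aromatic carbon. The unmeasured compound thus keeps the whole shared core and both indole arms, and only loses the methoxy group on one indole ring. Within the data shown here, with no measured step of this kind available, the expected change in this assay is small, with no direction that can be trusted beyond the scatter. The step from compound 3 to compound 4 is expected to be a 1.3-fold higher number from compound 3 to compound 4 (0.11 log units; within the scatter). Compound 4 is therefore estimated to give 6.5 ug/mL in this assay, within a range from 3 ug/mL to 14 ug/mL.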

Compound 4, half-maximal inhibitory concentration: 5.64 ug/mL
For compound 4 the middle estimate is 1.2-fold (0.06 log units) above the measured one; low and high end bracket the measured number.
By their numbers in this assay, from the lowest: compounds 3, 2 and 4 (each within the scatter of the next); then compound 1.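

Within the data shown here, until now, no two measured compounds differed in only one place, and compound 4 supplies two such comparisons in this assay. Replacing the methoxy group with hydrogen on an aromatic carbon, which turns 5-methoxy-2-methyl-1H-indol-3-yl into 2-methyl-1H-indol-3-yl, gives a 1.1-fold higher number from compound 3 to compound 4 (0.05 log units; within the scatter), so this readout does not separate the two arms and the methoxy group is not needed to keep the number in this range. The second comparison, at a different place, swaps methyl for phenyl on an aromatic carbon and gives a 1.0-fold higher number from compound 2 to compound 4 (0.01 log units; within the scatter), so this readout does not separate those two groups either, and nothing measured here offers an explanation for either result. The compounds shown leave open whether an amine or a carboxylic acid on the aromatic carbon that carries the methoxy group in compound 3 would give a number beyond the scatter, and whether a longer chain such as butyl would do so in place of the phenyl group of compound 4. On these data alone, it also remains open whether the methoxy-to-hydrogen swap would read the same in a compound carrying methyl instead of that phenyl group.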